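Adding a Second 2,5-Dihydroxybenzyl Arm to Compound 3

The compounds below may be only part of what the source reports. "The series", "measured", "known", "first", "only" and "open" are said of these compounds alone.

Compound 1 `Oc1ccc(O)c(COCc2cc(O)cc(Cl)c2O)c1`: 4300 nM
Compound 2 `OCc1cc(OCc2cc(O)ccc2O)ccc1O`: 6200 nM
Compound 3 `COCc1cc(O)c(Cc2cc(O)ccc2O)cc1O`: 6300 nM

In a functional assay (a lower number here means a stronger inhibitor, a higher number a weaker inhibitor), compound 3 gives the highest of the three numbers, yet compound 2 and compound 1 both sit within the usual scatter of it, so the three cannot be separated. Compound 4 `COCc1cc(O)c(Cc2cc(O)c(Cc3cc(O)ccc3O)cc2O)cc1O` is not yet measured. It differs from compound 3 by 2,5-dihydroxybenzyl in place of hydrogen on an aromatic carbon. Going by the values given here, no measured pair shows a change of this kind, so there is nothing direct to lean on. All three measured numbers lie in the same weak band. On that basis the step of a 1.6-fold lower number from compound 3 to compound 4 (0.20 log units; within the scatter) is expected to be small, perhaps a slight move toward stronger inhibition but not clearly beyond the scatter. Compound 4 is therefore estimated at 4000 nM, within 1500 nM to 12000 nM.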

Compound 4, half-maximal inhibitory concentration: 2600 nM
Compound 4: the middle estimate sits 1.5-fold (0.19 log units) above what was measured; the measured number falls inside the stated range.
By their numbers in this assay, from the lowest: compounds 4, 1, 2 and 3 (each within the scatter of the next, the first and the last beyond it).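

In this assay, going by these compounds alone, 2,5-dihydroxybenzyl in place of hydrogen on this aromatic carbon gives a 2.4-fold lower number from compound 3 to compound 4 (0.38 log units; beyond the scatter), the first single change in this set that can be read beyond the scatter. The position therefore accepts a large group carrying its own aromatic ring, and inhibition becomes modestly stronger. Nothing available here accounts for this gain.

From the compounds shown here alone, it remains open whether the gain depends on the two hydroxy groups of the new arm or on the ring alone. An unsubstituted benzyl group or a carboxylic acid at this carbon would help separate these possibilities.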